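The compounds below may be only part of what the source reports. "The series", "measured", "known", "first", "only" and "open" are said of these compounds alone.

Working notes on the series. In a functional assay on A549 cells (Homo sapiens) for inhibition, read by sulforhodamine B assay, with a stated time of 72 h (a lower number here means a stronger inhibitor of growth, a higher number a weaker inhibitor of growth), compound 1 `CCOC(=O)/C=C/c1ccncc1-c1ccc2c(cnn2C)c1` gives 5030 nM and compound 3 `CNC(=O)/C=C/c1ccncc1-c1ccc2cc[nH]c2c1` gives 7840 nM, two values within the usual scatter of each other. Compound 2 `NNC(=O)CCc1ccncc1-c1ccc2ccccc2c1` reads > 10000 nM, which is a limit of the assay and not a number. For the measured compounds named here, compound 1 therefore stands level with compound 3, and these are the only two numbers available.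

Compound 4 `Cn1ncc2cc(-c3cnccc3/C=C/C(=O)O)ccc21` departs from compound 1 at a single place: hydrogen in place of ethyl on an oxygen next to a carbonyl group. This is hydrogen in place of ethyl on an oxygen next to a carbonyl group, so ethoxycarbonyl becomes carboxy. Going by the values given here, no measured pair shows this change, so the expectation is loose. A moderate step towards a higher number in this assay is expected, somewhat beyond the scatter, and the estimated 2.2-fold higher number from compound 1 to compound 4 (0.34 log units; beyond the scatter) reflects this. The series already contains (the limit of > 10000 nM in this assay, at which 1 of the 3 values shown sits), so a limit rather than a number is a real possibility for compound 4. Compound 4 is estimated at 11000 nM, with an expected range of 5000 nM to 25000 nM.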

Compound 4, concentration for 50% growth inhibition: > 10000 nM
Compound 4: only a limit was reported; the forecaster's own chance of this, stated with the estimate: 55%; the middle value lies beyond the limit too.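

For the compounds shown here, this is the first change made at a single place, ethoxycarbonyl to carboxy, and in this assay compound 4 gives > 10000 nM, which is a limit of the assay and not a number. Going by these compounds alone, the only step available is an at least 1.9-fold higher number from compound 1 to compound 4 (0.29 log units; that floor lies within the scatter), so the size of this change at this oxygen is known only as a floor, and that floor alone does not establish a real difference in growth inhibition. The limit of the assay now takes in more of the series: the limit of > 10000 nM in this assay, at which 2 of the 4 values shown sit.

The compounds shown leave open how a methyl or a longer butyl chain on this oxygen would read, and so whether ethyl itself matters or any carbon chain there would serve. They also leave open what an amine in place of this oxygen would give on the core of compound 1.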